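Swapping pyridin-2-yl for pyridin-4-yl on the shared core

The compounds below may be only part of what the source reports. "The series", "measured", "known", "first", "only" and "open" are said of these compounds alone.

Compound 1 `Cc1ccc2c(c1)c([C@H](C)Nc1ncnc3[nH]cnc13)nn2-c1cccnc1`: > 40000 nM
Compound 2 `C[C@H](Nc1ncnc2[nH]cnc12)c1nn(-c2ccccn2)c2cc(F)ccc12`: > 40000 nM

Both compounds were tested in a functional assay on Hep 3B2 cells (Homo sapiens) for inhibition, read by sulforhodamine B assay, with a stated time of 72 h; a lower number here means a stronger inhibitor, a higher number a weaker inhibitor. Compound 1 gives > 40000 nM, which is a limit of the assay and not a number. Compound 2 gives > 40000 nM, and this too is only a limit. The record so far therefore comes down to the limit of > 40000 nM in this assay, at which 2 of the 2 values shown sit, and compound 2 has no exact value from which to measure a change.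

The next compound is compound 3 `C[C@H](Nc1ncnc2[nH]cnc12)c1nn(-c2ccncc2)c2cc(F)ccc12`. It has the same atoms as compound 2, joined differently: pyridin-4-yl in place of pyridin-2-yl on an aromatic nitrogen. In words, pyridin-4-yl stands in place of pyridin-2-yl on an aromatic nitrogen.

Among the compounds with values here, no step between measured compounds is available as a guide. In this assay, no change beyond the scatter is expected, because compound 2 sits at > 40000 nM and the swap leaves the counted features of the group the same. The estimate amounts to an expected a number no higher from compound 2 to compound 3 (the limit leaves the size open). Compound 3 is expected at 40000 nM, with an estimated range of 12000 nM to 60000 nM, and the assay may well report only a limit again.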

Compound 3, half-maximal inhibitory concentration: 21400 nM
For compound 3 the middle estimate is 1.9-fold (0.27 log units) above the measured one, within the range that was stated.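

In this assay compound 3 gives 21400 nM, the first exact number among the compounds shown, so pyridin-4-yl on this aromatic nitrogen yields a value that can be read rather than a limit. Placing pyridin-4-yl where pyridin-2-yl stood gives an at least 1.8-fold lower number from compound 2 to compound 3 (0.27 log units; that floor lies within the scatter), and because only a floor is available, this result does not establish a real difference between the two groups, though it leaves room for one of any larger size. Exact values remain the exception in this small set, and the limit still marks most of the record: the limit of > 40000 nM in this assay, at which 2 of the 3 values shown sit.

The compounds shown leave open how far the true value of compound 2 lies from that of compound 3, and so whether the change from pyridin-2-yl to pyridin-4-yl matters at all in this assay. They also leave open whether a plain phenyl ring on the same aromatic nitrogen, or a pyridin-4-yl bearing an amine, would give a number clearly lower than that of compound 3.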